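Chloro Substitution on Two Isatin-Type Cores

The source may hold more compounds than are shown below. What is called first, only, known or untested is meant among the compounds shown, and "the series" means these compounds.

Measured compounds:
compound 1 `O=C1C(=O)N(CN(c2ccccc2)c2ccccc2)c2cccc(Cl)c21` — 31400 nM
compound 2 `O=C1C(=O)N(CN(c2ccccc2)c2ccccc2)c2ccccc21` — 24800 nM
compound 3 `CN(C)CN1C(=O)C(=O)c2ccccc21` — 65600 nM

In a functional assay on MDA-MB-231 cells (Homo sapiens) for cytotoxicity, read by sulforhodamine B assay, with a stated time of 48 h (on this read-out higher numbers stand for weaker inhibition of growth and lower numbers for stronger inhibition of growth), compound 2 gives 24800 nM and compound 1 gives 31400 nM. The change between them, (chloro in place of hydrogen on an aromatic carbon), made a 1.3-fold higher number from compound 2 to compound 1 (0.10 log units; within the scatter). Compound 3 gives 65600 nM; how its core differs from that of compound 2 is not broken down here. Compound 4 `CN(C)CN1C(=O)C(=O)c2c(Cl)cccc21` has not been measured; it differs from compound 3 by chloro in place of hydrogen on an aromatic carbon, the same change as from compound 2 to compound 1 at the same kind of place. Because a 1.3-fold higher number from compound 2 to compound 1 (0.10 log units; within the scatter) stayed within the scatter, a similarly small step, a 1.2-fold higher number from compound 3 to compound 4 (0.09 log units; within the scatter), is expected in this assay. Compound 4 is thus estimated at 80000 nM, between 40000 nM and 160000 nM, resting on compound 3 alone and this single earlier example.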

Compound 4, concentration for 50% growth inhibition: 138000 nM
Estimate against measurement, compound 4: 1.7-fold (0.24 log units) below; measured number inside the range.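

In this assay, chloro in place of hydrogen on an aromatic carbon gave a 2.1-fold higher number from compound 3 to compound 4 (0.32 log units; beyond the scatter), a step that lies beyond the scatter, yet the two cores do not clearly part ways on this change: the same change on two cores in this assay, a 1.3-fold higher number (0.10 log units; within the scatter) from compound 2 to compound 1 and a 2.1-fold higher number (0.32 log units; beyond the scatter) from compound 3 to compound 4, 1.7-fold (0.22 log units) apart, within the scatter of two such steps

These two pairs therefore give no sign that the core alters what this change does. For the compounds shown here, this rests on only two pairs, however, and it neither proves that the two steps are equal nor says how the change would behave on any other core.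

The compounds shown leave open whether another group at the same place, such as fluoro, methoxy or a carboxylic acid, would behave alike on both cores. They also leave open what a cyclic amine such as piperidine would do in place of the dimethylamino or diphenylamino group.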